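The source may hold more compounds than are shown below. What is called first, only, known or untested is meant among the compounds shown, and "the series" means these compounds.

Measured in a functional assay on HeLa cells (Homo sapiens) for cytotoxicity, read by MTT assay; a lower number here means a stronger inhibitor, a higher number a weaker inhibitor:

Compound 1 (`CCCCCCCCCC(O)CNC(C)=O`) gives "not active" (no number reported)
Compound 2 (`COC(=O)CCCCCCCCC(O)CN`) gives 3590 nM

For the measured compounds named here, compound 2 carries the only number in this small set (3590 nM). Compound 1 was reported without one, so the two cannot be ranked by a number. Compound 3 (`NCC(O)CCCCCCCCCO`) differs from compound 2 by a single change (hydroxymethyl in place of methoxycarbonyl on a saturated chain carbon, nine bonds along the chain from an oxygen on a saturated carbon): hydroxymethyl in place of methoxycarbonyl on a saturated chain carbon, nine bonds along the chain from an oxygen on a saturated carbon. Going by the values given here, no measured pair shows what this change does in this assay, so the expectation rests on compound 2 alone. A modest weakening is expected, toward a higher number, and the estimated step is small (a 2.2-fold higher number from compound 2 to compound 3 (0.35 log units; beyond the scatter)). For compound 3 the estimated value is 8000 nM and the expected range runs from 2500 nM to 25000 nM in this assay (an estimate, not a measurement).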

Compound 3, half-maximal inhibitory concentration: 8790 nM
Beside the measured number, compound 3's estimate is 1.1-fold (0.04 log units) below it; the range from low to high includes it.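

In this assay, for the compounds shown here, this pair gives the first measured reading of this change: hydroxymethyl in place of methoxycarbonyl, on a saturated chain carbon, nine bonds along the chain from an oxygen on a saturated carbon, produces a 2.4-fold higher number from compound 2 to compound 3 (0.39 log units; beyond the scatter). The group at this place therefore affects the number, yet a measurable value remains without methoxycarbonyl, as compound 3 gives 8790 nM. No measured property of either group is available to explain the step.

From the compounds shown here alone, whether a carboxylic acid or an amine at this place would give a value nearer that of compound 2 or compound 3 stays open, as does the effect of a longer chain. In this assay compound 1 gives "not active" (no number reported), so it offers no number to set against the others and cannot settle these questions.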